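From sec-Butyl to Cyclopentyl at the Amide Carbonyl

A few compounds are considered here, and "the series" means these few. Any claim that something is new, unique, unknown or untested is made for them only; others in the source may bear on it.

Three amides sharing one core have been measured in an assay on LtK cells with ATP-sensitive inward rectifier potassium channel 11 (Homo sapiens) as the target; a lower number here means that less compound is needed, a higher number that more compound is needed for the effect. Compound 1 `CCC(C)C(=O)Nc1c(C(O)(C(F)(F)F)C(F)(F)F)ccc2ccccc12` gives 177000 nM, the highest of the three numbers. Compound 2 `CCC(CC)C(=O)Nc1c(C(O)(C(F)(F)F)C(F)(F)F)ccc2ccccc12` gives 4340 nM, and compound 3 `O=C(Nc1c(C(O)(C(F)(F)F)C(F)(F)F)ccc2ccccc12)C1CC1` gives 751 nM. The change from compound 1 to compound 4 `O=C(Nc1c(C(O)(C(F)(F)F)C(F)(F)F)ccc2ccccc12)C1CCCC1` is cyclopentyl in place of sec-butyl on a carbonyl carbon. Two measured steps start from compound 1 and bear on this change: a 41-fold lower number from compound 1 to compound 2 (1.61 log units; beyond the scatter) and a 240-fold lower number from compound 1 to compound 3 (2.37 log units; beyond the scatter), both large drops in the number needed. The remaining pair, a 5.8-fold lower number from compound 2 to compound 3 (0.76 log units; beyond the scatter), shows a more modest drop. A large downward step is therefore expected for compound 4. The step from compound 1 to compound 4 is estimated at a 59-fold lower number from compound 1 to compound 4 (1.77 log units; beyond the scatter). Compound 4 is expected to give 3000 nM, within a likely range from 500 nM to 20000 nM.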

Compound 4, half-maximal effective concentration: 495 nM
Beside the measured number, compound 4's estimate is 6.1-fold (0.78 log units) above it; measured number outside the range, below it.
By their numbers in this assay, from the lowest: compounds 4 and 3 (each within the scatter of the next); then compound 2; then compound 1.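

In this assay cyclopentyl on this carbonyl carbon matches cyclopropyl, with a 1.5-fold lower number from compound 3 to compound 4 (0.18 log units; within the scatter) as the step, so these two rings cannot be ordered. Against the open chains, the change gives a 360-fold lower number from compound 1 to compound 4 (2.55 log units; beyond the scatter) from sec-butyl and an 8.8-fold lower number from compound 2 to compound 4 (0.94 log units; beyond the scatter) from pentan-3-yl, which places both ring compounds below both chain compounds. Nothing available explains this difference between rings and chains.

The compounds shown leave open how a cyclobutyl or cyclohexyl ring would compare at this position. They also leave open whether a phenyl ring or a piperidine ring would keep the number this low.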